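Varying the Heteroaryl Ether on a Peptidyl Ketone Core

The source may report more compounds than this note shows. Statements on the series, on what has been measured and on what is new or still open speak of the compounds shown alone.

Compound 1 `COC(=O)c1cc(OCC(=O)[C@H](CC(=O)O)NC(=O)[C@@H](NC(=O)COc2cccc3ccccc23)C(C)C)no1`: 71000 nM
Compound 2 `CC(C)[C@H](NC(=O)COc1cccc2ccccc12)C(=O)N[C@@H](CC(=O)O)C(=O)CSc1nnnn1-c1ccccc1`: 153000 nM
Compound 3 `CC(C)[C@H](NC(=O)COc1cccc2ccccc12)C(=O)N[C@@H](CC(=O)O)C(=O)COc1ccc2ccccc2n1`: > 200000 nM, a limit of the assay

In a functional assay on Jurkat cells (Homo sapiens) for inhibition (a lower number here means a stronger inhibitor, a higher number a weaker inhibitor), compound 1 gives 71000 nM, the lowest number of the three. The step of a 2.2-fold higher number from compound 1 to compound 2 (0.33 log units; beyond the scatter) is a modest loss. Compound 3 stands at the limit (the limit of > 200000 nM in this assay, at which 1 of the 3 values shown sits); the steps of an at least 2.8-fold higher number from compound 1 to compound 3 (0.44 log units; beyond the scatter) and an at least 1.3-fold higher number from compound 2 to compound 3 (0.11 log units; that floor lies within the scatter) are therefore floors only, and the second of them does not reach beyond the scatter.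

Compound 4 `CC(C)[C@H](NC(=O)COc1cccc2ccccc12)C(=O)N[C@@H](CC(=O)O)C(=O)COn1nnc2ccccc2c1=O` keeps the whole of the shared core and differs from compound 3 only in the group on the ether oxygen: a group of 11 heavy atoms (7 carbon, 3 nitrogen, 1 oxygen; one six-membered aromatic ring of carbon only, one six-membered aromatic ring with 3 hetero atoms) in place of a group of 10 heavy atoms (9 carbon, 1 nitrogen; one six-membered aromatic ring of carbon only, one six-membered aromatic ring with 1 hetero atom), on an oxygen on a saturated carbon. The two measured steps that bear on this kind of change, the exchange of the ring group carried by that oxygen or sulfur, moved the number only modestly, and compound 3 itself already sits at the limit. The expected step is therefore a number no higher from compound 3 to compound 4 (the limit leaves the size open), with no direction claimed beyond the scatter. Compound 4 is expected to give about 200000 nM, within a range of 80000 nM to 500000 nM.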

Compound 4, half-maximal inhibitory concentration: 137000 nM
Compound 4: the middle estimate sits 1.5-fold (0.16 log units) above what was measured; the range from low to high includes it.
By their numbers in this assay, from the lowest: compounds 1, 4 and 2 (each within the scatter of the next, the first and the last beyond it). At a limit, above all of these: compound 3.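

From the compounds shown here alone, exchanging quinolin-2-yl for the new group on an oxygen on a saturated carbon brings a readable number in this assay (an at least 1.4-fold lower number from compound 3 to compound 4 (0.16 log units; that floor lies within the scatter)), but that step is a floor and its true size stays unknown. Set against the other two groups, the new one stands apart from neither (a 1.1-fold lower number from compound 2 to compound 4 (0.05 log units; within the scatter); a 1.9-fold higher number from compound 1 to compound 4 (0.29 log units; within the scatter)), even though the two steps printed earlier from compound 1 lay beyond the scatter. Compound 3 remains a limit of the assay: (the limit of > 200000 nM in this assay, at which 1 of the 4 values shown sits).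

The compounds shown leave open how a group with no ring at all, such as a plain methyl or a longer carbon chain, would read on this oxygen. They also leave open whether an amine or a carboxylic acid on the entering ring would move the number beyond the scatter.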